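The compounds below may be only part of what the source reports. "The series", "measured", "known", "first", "only" and "open" are said of these compounds alone.

Measured compounds in a functional assay on A-375 cells (Homo sapiens) for cytotoxicity, read by MTT assay; a higher number here means a weaker inhibitor, a lower number a stronger inhibitor:
compound 1 `COc1ccc(/C=C/C(=O)c2ccc(OC)c3c2OC(C)(C)C=C3)cc1OCCO` — 9600 nM
compound 2 `CCCCC(=O)Oc1cc(/C=C/C(=O)c2ccc(OC)c3c2OC(C)(C)C=C3)ccc1OC` — 220 nM

Within the data shown here, compound 1 stands highest of the two numbers so far; its nearest neighbour is compound 2, and the only measured step, a 44-fold lower number from compound 1 to compound 2 (1.64 log units; beyond the scatter), is a large drop that comes with butylcarbonyl in place of 2-hydroxyethyl on an oxygen on an aromatic ring. Among the measured compounds shown here, that is the sole step that bears on the present question.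

Compound 3 `COc1cccc(C(=O)Oc2cc(/C=C/C(=O)c3ccc(OC)c4c3OC(C)(C)C=C4)ccc2OC)c1` is not yet measured in this assay. Against compound 1 it carries (3-methoxyphenyl)carbonyl in place of 2-hydroxyethyl on an oxygen on an aromatic ring. The change sits at the same oxygen as in compound 2 and again turns the 2-hydroxyethyl into an acyl group, this time (3-methoxyphenyl)carbonyl rather than butylcarbonyl. Only one acyl variant is known, so how far a larger aromatic acyl tracks the butylcarbonyl result is open; the expectation is nonetheless a step of the same direction and broadly the same size, with a wide range to cover that uncertainty.

Compound 3 is therefore expected to give 300 nM in this assay, between 60 nM and 1500 nM, which means an expected step of a 32-fold lower number from compound 1 to compound 3 (1.51 log units; beyond the scatter).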

Compound 3, half-maximal inhibitory concentration: 800 nM
Compound 3: the middle estimate sits 2.7-fold (0.43 log units) below what was measured; the range from low to high includes it.
By their numbers in this assay, from the lowest: compound 2; then compound 3; then compound 1.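

In this assay, the oxygen on an aromatic ring that carries 2-hydroxyethyl in compound 1 now has two acyl replacements, and the second also gives a large fall, with a 12-fold lower number from compound 1 to compound 3 (1.08 log units; beyond the scatter); the drop is therefore not confined to butylcarbonyl. The identity of the acyl group still matters: 3-methoxyphenyl in place of butyl on a carbonyl carbon gives a 3.6-fold higher number from compound 2 to compound 3 (0.56 log units; beyond the scatter), a modest step that gives back part of the gain. An aromatic ring on the carbonyl carbon is thus tolerated at this oxygen, and in the compounds shown both acyl groups give lower numbers than 2-hydroxyethyl, with no compound going against that order.

Nothing available explains why either acyl group lowers the number or why butyl gives a lower number than 3-methoxyphenyl. Going by these compounds, it remains open whether the carbonyl itself is required, which a plain butyl group or an aminoethyl group on the same oxygen would test, and whether a chain longer than butyl on the carbonyl carbon would lower the number further.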